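Thioester in place of amide on the shared core

The source may report more compounds than this note shows. Statements on the series, on what has been measured and on what is new or still open speak of the compounds shown alone.

Measured so far in an assay on membranes from CHO cells for displacement of a labelled ligand from adenosine receptor A1 (Homo sapiens), read by scintillation counting, with a stated time of 60 min, tested at 1 uM; a higher number here means more inhibition at the concentration tested (going by the name of the read-out), a lower number less inhibition:
compound 1 `CC1=C(C(=O)CC(C)C)C(c2ccco2)NC(=O)N1` gives 16%
compound 2 `CCNC(=O)C1=C(C)NC(=O)NC1c1ccco1` gives 2%
compound 3 `CCN(CC)C(=O)C1=C(C)NC(=O)NC1c1ccco1` gives 11%

Compound 3 stands in the middle of these three numbers: against compound 1 it shows a number 5 percentage points lower from compound 1 to compound 3 (within the scatter), and against compound 2 it shows a number 9 percentage points higher from compound 2 to compound 3 (within the scatter), so compound 3 is set apart from neither of its neighbours. Within the data shown here, the only step beyond the scatter is a number 14 percentage points lower from compound 1 to compound 2 (beyond the scatter).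

Compound 4 `CCSC(=O)C1=C(C)NC(=O)NC1c1ccco1` differs from compound 3 at the carbonyl carbon: ethylsulfanyl in place of diethylamino on a carbonyl carbon. The three measured steps all change what hangs on that carbonyl carbon, and two of them stay within the scatter, while the third is modest. A further change at the same place is therefore expected to move this assay little, with no clear direction. The expected step is a number 1 percentage points lower from compound 3 to compound 4 (within the scatter). Compound 4 is estimated at 10%, with a range from 0% to 24%.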

Compound 4, a percentage reported as inhibition, at one concentration (the size of the read-out at that concentration, not a potency): 6%
The estimate for compound 4 lay 4 percentage points above the measured number; measured number inside the range.
By their numbers in this assay, from the lowest: compounds 2, 4, 3 and 1 (each within the scatter of the next, the first and the last beyond it).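

Putting ethylsulfanyl on the carbonyl carbon, so that a sulfur now joins the group to it, brings no step beyond the scatter in this assay: replacing diethylamino gives a number 5 percentage points lower from compound 3 to compound 4 (within the scatter), replacing ethylamino gives a number 4 percentage points higher from compound 2 to compound 4 (within the scatter), and replacing isobutyl gives a number 10 percentage points lower from compound 1 to compound 4 (within the scatter). This position has now carried groups joined through carbon, nitrogen and sulfur, and the sulfur-joined group cannot be told apart from any of the others, so compound 4 adds no new separation to the series. Nothing at hand explains these small differences.

Still open, from the compounds shown here alone, is how an ethoxy group, a carboxylic acid or a longer alkyl chain on the same carbonyl carbon would behave. The compounds shown also leave open whether a phenyl group there would give inhibition clearly beyond this narrow band.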